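Adding One Fluoro to Compound 2

The compounds below may be only part of what the source reports. "The series", "measured", "known", "first", "only" and "open" are said of these compounds alone.

Compound 1 `COc1ccnc(Nc2cc3[nH]c(-c4cccc(C(F)(F)F)c4)nc3cn2)c1` gives 71%
Compound 2 `Fc1ccc(Nc2cc3[nH]c(-c4cccc(C(F)(F)F)c4)nc3cn2)nc1` gives 42%

Both compounds were tested in an ADME assay on microsomes from liver (Rattus norvegicus) for metabolic stability, read by LC-MS, with a stated time of 30 min, tested at 0.1 uM (on this read-out higher numbers stand for a more stable compound and lower numbers for a less stable compound), and compound 2 (42%) holds the lower of the two numbers. The next compound, compound 3 `Fc1ccc(Nc2cc3[nH]c(-c4ccc(F)c(C(F)(F)F)c4)nc3cn2)nc1`, changes it in one place: fluoro in place of hydrogen on an aromatic carbon. This is fluoro in place of hydrogen on an aromatic carbon, ortho to a trifluoromethyl group, on the six-membered aromatic ring of carbon only.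

Within the data shown here, only one measured step is available, a number 29 percentage points lower from compound 1 to compound 2 (beyond the scatter). It is modest but beyond the scatter. That step, however, put 5-fluoropyridin-2-yl in place of 4-methoxypyridin-2-yl, so it happened elsewhere in the molecule and involved a different exchange. It offers a sense of how far one change can move this read-out, but it gives no direction for the new fluoro. Among the measured compounds shown here, no measured pair tests this place, so only a small rise is expected, within the scatter and held with little confidence. The estimated step is a number 5 percentage points higher from compound 2 to compound 3 (within the scatter) in this assay. Compound 3 is expected to give 47%, with an estimated range from 30% to 64%.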

Compound 3, percent of the compound remaining: 91%
Estimate against measurement, compound 3: 44 percentage points below; the whole stated range lies below it.
By their numbers in this assay, from the lowest: compound 2; then compound 1; then compound 3.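

Replacing a single hydrogen with fluoro on an aromatic carbon, ortho to a trifluoromethyl group, gives a number 49 percentage points higher from compound 2 to compound 3 (beyond the scatter) in this assay, which is a large move for the addition of one heavy atom. Among these compounds, the earlier pair changed a different part of the molecule, so this is the first sign that the six-membered aromatic ring of carbon only is a sensitive place for this read-out, and that a very small edit there can matter more than its size suggests. The compounds show how far the number moved, but no measurement bears on the reason for the move.

The compounds shown leave open whether this step belongs to fluoro itself or would follow from other replacements of that hydrogen, a question that a chlorine atom, a methoxy group or a nitrile on the same carbon would help to answer. Going by these compounds, it also remains open whether the same fluoro would produce a similar step when the 4-methoxypyridin-2-yl group of compound 1 takes the place of the 5-fluoropyridin-2-yl group.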